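Working notes: fluoro for hydrogen in a cytotoxicity series

The source may report more compounds than this note shows. Statements on the series, on what has been measured and on what is new or still open speak of the compounds shown alone.

Measured compounds:
compound 1 `COc1cccc(-c2cc(C(=O)Nc3ccc(Oc4ccnc5cc(OCCCN6CCCCC6)c(OC)cc45)c(F)c3)c3ccccc3n2)c1` gives 210 nM in a functional assay on NCI-H460 cells (Homo sapiens) for cytotoxicity, read by MTT assay, with a stated time of 72 h; on this read-out lower numbers stand for stronger inhibition and higher numbers for weaker inhibition
compound 2 `COc1cc2c(Oc3ccc(NC(=O)c4cc(-c5cccc(Cl)c5)nc5ccccc45)cc3F)ccnc2cc1OCCCN1CCC(C)CC1` gives 65 nM in this assay
compound 3 `COc1cccc(-c2cc(C(=O)Nc3ccc(Oc4ccnc5cc(OCCCN6CCCCC6)c(OC)cc45)c(F)c3)c3cc(F)ccc3n2)c1` gives 1000 nM in this assay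

Compound 3 is compound 1 carrying (fluoro in place of hydrogen on an aromatic carbon). That single change produces a 4.8-fold higher number from compound 1 to compound 3 (0.68 log units; beyond the scatter). Compound 2 stands apart from compound 1 in more than one place; the difference between the two cores is not broken down here. Compound 2 gives the lowest number of the three measured, with compound 1 as its nearest neighbour and compound 3 as the furthest.

Compound 4 `COc1cc2c(Oc3ccc(NC(=O)c4cc(-c5cccc(Cl)c5)nc5ccc(F)cc45)cc3F)ccnc2cc1OCCCN1CCC(C)CC1` is the not yet measured partner of compound 2, carrying (fluoro in place of hydrogen on an aromatic carbon). The surroundings of the entering fluoro are described in the same words for both pairs, so this is the same change, applied to the core of compound 2 rather than to that of compound 1. Within the data shown here, only one measured instance of the change exists, and whether the core of compound 2 responds in the same way is untested. On that basis the step from compound 2 to compound 4 is expected to be a 4.6-fold higher number from compound 2 to compound 4 (0.66 log units; beyond the scatter), set beside the measured 4.8-fold higher number from compound 1 to compound 3 (0.68 log units; beyond the scatter). Compound 4 is estimated at 300 nM in this assay, with an expected range from 120 nM to 750 nM.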

Compound 4, half-maximal inhibitory concentration: 60 nM
Compound 4: the middle estimate sits 5.0-fold (0.70 log units) above what was measured, and the stated range ends above it.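

Across the two cores in this assay, fluoro in place of hydrogen on an aromatic carbon does not behave as a constant step: the same change on two cores in this assay, a 4.8-fold higher number (0.68 log units; beyond the scatter) from compound 1 to compound 3 and a 1.1-fold lower number (0.03 log units; within the scatter) from compound 2 to compound 4, 5.2-fold (0.71 log units) apart, beyond the scatter of two such steps. On the core of compound 2, the change gives a 1.1-fold lower number from compound 2 to compound 4 (0.03 log units; within the scatter), so compound 2 and compound 4 cannot be told apart in this read-out, and the penalty seen on the core of compound 1 cannot be assumed to carry over to a related core in this series. Among these compounds, with only two pairs, and with cores that differ in more than one place, the data do not show which of those differences goes with the gap, why the gap arises, or which of the two steps is more typical of the series.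

Still open, on these data alone, is how the step would behave on a core carrying only one of the differences between the cores of compound 1 and compound 2, which would help separate their contributions. Also open, as far as these compounds go, is whether a group other than fluoro on the same aromatic carbon, such as a nitrile or a trifluoromethyl group, would follow the same core dependence in this assay.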